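From compound 2 to compound 4: a fluoro step

The compounds below may be only part of what the source reports. "The series", "measured", "known", "first", "only" and "open" are said of these compounds alone.

Compound 1 `COC(=O)NC1=NC(c2ccccc2)CN1C`: 107 mg/kg
Compound 2 `CCOC(=O)NC1=NC(c2ccccc2)CN1C`: 78 mg/kg
Compound 3 `CC(C)COC(=O)NC1=NC(c2ccccc2)CN1C`: 70 mg/kg

All three compounds were tested in a functional assay on the whole organism for antagonist activity, with Mus musculus as the target, in the maximal electroshock model; a higher number here means that more compound is needed for the effect, a lower number that less compound is needed. There compound 2 stands at 78 mg/kg, within the scatter of both other compounds, as a 1.4-fold lower number from compound 1 to compound 2 (0.14 log units; within the scatter) and a 1.1-fold lower number from compound 2 to compound 3 (0.05 log units; within the scatter) show. Compound 4 `CCOC(=O)NC1=NC(c2ccc(F)cc2)CN1C` keeps the ethyl chain of compound 2 and has fluoro in place of hydrogen on an aromatic carbon, para to a large group (fluoro in place of hydrogen on an aromatic carbon).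

Within the data shown here, no measured step makes this change. All three measured steps alter the chain bound to the oxygen next to the carbonyl group, and the aromatic ring stays unsubstituted throughout. They show only that the series is flat at that place, with a 1.5-fold lower number from compound 1 to compound 3 (0.18 log units; within the scatter) as the third example. They give no direction for the fluoro change, so only a small step is expected in this assay, with nothing beyond the scatter foreseen. The expected change is a 1.2-fold lower number from compound 2 to compound 4 (0.08 log units; within the scatter). For compound 4 the estimate is 65 mg/kg, with an expected range from 32 mg/kg to 130 mg/kg.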

Compound 4, dose for half-maximal effect: 100 mg/kg
Estimate against measurement, compound 4: 1.5-fold (0.19 log units) below, and the stated range covers the measured number.
By their numbers in this assay, from the lowest: compounds 3, 2, 4 and 1 (each within the scatter of the next).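

In this assay, among these compounds, fluoro in place of hydrogen on an aromatic carbon, para to a large group, gives a 1.3-fold higher number from compound 2 to compound 4 (0.11 log units; within the scatter), the first reading at the aromatic ring, which stayed unsubstituted in compounds 1, 2 and 3. This single step places the ring alongside the chain bound to the oxygen next to the carbonyl group as a place where one change has so far stayed within the scatter. Nothing available here explains the number of compound 4.

As far as these compounds go, what a chloro or a methoxy group at this same place would give remains open, as does whether fluoro would give a step of similar size on compound 1 or compound 3. Equally open, from the compounds shown here alone, is how an amine on the chain bound to the oxygen would read in this assay.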